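This account rests on a few compounds, and the source may have more. Where it says the series, first, only, none or still open, it means among the compounds named here.

Compound 3 (`Cc1ccccc1N1CCN(CCCCNC(=O)c2ccc3ccccc3c2)CC1`) gives 29.9 nM in an assay on isolated protein for displacement of a labelled ligand from Alpha-1A adrenergic receptor (Homo sapiens) (on this read-out higher numbers stand for weaker inhibition and lower numbers for stronger inhibition), the lowest number of the three measured. Compound 1 (`Cc1cccc(N2CCN(CCCCNC(=O)c3ccc4ccccc4c3)CC2)c1C`) gives 230 nM and compound 2 (`CCOC(=O)Nc1cccc(N2CCN(CCCCNC(=O)c3ccc4ccccc4c3)CC2)c1`) gives 1030 nM, so compound 3 stands apart from both beyond the scatter. Compound 4 (`O=C(NCCCCN1CCN(c2cccc(C(F)(F)F)c2)CC1)c1ccc2ccccc2c1`) differs from compound 3 in one place: 3-(trifluoromethyl)phenyl in place of 2-methylphenyl on an amine nitrogen in a ring. Among the measured compounds shown here, no measured pair shows exactly this exchange. The step of a 7.7-fold lower number from compound 1 to compound 3 (0.89 log units; beyond the scatter) shows that removing a methyl from the aromatic ring on the ring amine lowered the number, and the values of compound 3 and compound 2 show that a different substituted phenyl on the same nitrogen goes with a much higher number. Both point the same way: the phenyl of compound 3 gives the lowest number seen, and a changed substitution pattern on it has so far raised the number. Compound 4 is therefore expected to show a modest rise, a 5.0-fold higher number from compound 3 to compound 4 (0.70 log units; beyond the scatter), because the step of a 7.7-fold lower number from compound 1 to compound 3 (0.89 log units; beyond the scatter) went the other way. The estimate for compound 4 is 150 nM, between 40 nM and 600 nM.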

Compound 4, inhibition constant: 283 nM
For compound 4 the middle estimate is 1.9-fold (0.28 log units) below the measured one, and the stated range covers the measured number.
By their numbers in this assay, from the lowest: compound 3; then compounds 1 and 4 (each within the scatter of the next); then compound 2.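

In this assay the exchange of 2-methylphenyl for 3-(trifluoromethyl)phenyl on the amine nitrogen gives a 9.5-fold higher number from compound 3 to compound 4 (0.98 log units; beyond the scatter) and so adds a further substituted phenyl that does not reach the number of compound 3. Trifluoromethyl in place of (ethoxycarbonyl)amino gives a 3.6-fold lower number from compound 2 to compound 4 (0.56 log units; beyond the scatter) and shows that the number also moves among these other substituted phenyls, while a 1.2-fold higher number from compound 1 to compound 4 (0.09 log units; within the scatter) leaves 3-(trifluoromethyl)phenyl and 2,3-dimethylphenyl indistinguishable here. No measured property on hand accounts for any of these steps.

The exchange alters both the group and its place on the phenyl, so the compounds shown cannot separate the two. Also open, as far as these compounds go, is how a plain phenyl, or a methoxy group or a chlorine atom on that phenyl, would fare on this nitrogen.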